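Amide Substituent Variation on the Shared Core: Compound 4

This account rests on a few compounds, and the source may have more. Where it says the series, first, only, none or still open, it means among the compounds named here.

Measured compounds in a functional assay on PC-3 cells (Homo sapiens) for antiproliferative activity, read by MTT assay, with a stated time of 24 h; a lower number here means a stronger inhibitor, a higher number a weaker inhibitor:
Compound 1, `CCn1c(C(=O)N[C@H](C)C(=O)OC)ccc1C(CC)(CC)c1ccc(OCS(=O)(=O)c2ccccc2)c(C)c1`, gives > 50000 nM; this is a limit of the assay, not a number.
Compound 2, `CCN(CC)CCNC(=O)c1ccc(C(CC)(CC)c2ccc(OCS(=O)(=O)c3ccccc3)c(C)c2)n1CC`, gives 7130 nM.
Compound 3, `CCn1c(C(=O)N[C@@H](CO)CCO)ccc1C(CC)(CC)c1ccc(OCS(=O)(=O)c2ccccc2)c(C)c1`, gives 14100 nM.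

Compound 2 stands at the lowest of the two numbers in this assay. Among the measured compounds shown here, its nearest neighbour is compound 3, a 2.0-fold higher number from compound 2 to compound 3 (0.30 log units; within the scatter), and the only other value shown is a limit, so compound 2 cannot be called the most potent. Compound 4, `CCn1c(C(=O)N[C@H](C(=O)O)C(C)C)ccc1C(CC)(CC)c1ccc(OCS(=O)(=O)c2ccccc2)c(C)c1`, is not yet measured. The change from compound 2 is 1-carboxy-2-methylpropyl in place of 2-(diethylamino)ethyl on an amide-type nitrogen. For the measured compounds named here, the steps that bear on it are an at least 7.0-fold lower number from compound 1 to compound 2 (0.84 log units; beyond the scatter) and a 2.0-fold higher number from compound 2 to compound 3 (0.30 log units; within the scatter); compound 1 sits at the limit of > 50000 nM in this assay, at which 1 of the 3 values shown sits. In its substituent on the amide-type nitrogen compound 4 resembles compound 1 more closely than compound 2, and the step from compound 1 to compound 2 was the larger one. A higher number is therefore expected for compound 4, estimated as a 4.2-fold higher number from compound 2 to compound 4 (0.62 log units; beyond the scatter). The estimate for compound 4 is 30000 nM, expected to lie between 10000 nM and 90000 nM, with a real chance that only a limit is reported.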

Compound 4, half-maximal inhibitory concentration: 3650 nM
For compound 4 the middle estimate is 8.2-fold (0.91 log units) above the measured one; measured number outside the range, below it.
By their numbers in this assay, from the lowest: compounds 4, 2 and 3 (each within the scatter of the next, the first and the last beyond it). At a limit, above all of these: compound 1.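

In this assay, a substituent without an amine matches the one with it at this amide-type nitrogen: a 2.0-fold lower number from compound 2 to compound 4 (0.29 log units; within the scatter), so the diethylamino group of compound 2 is not required for activity at this level. The other two substituents are separated from 1-carboxy-2-methylpropyl, with a 3.9-fold lower number from compound 3 to compound 4 (0.59 log units; beyond the scatter) and, against 1-(methoxycarbonyl)ethyl, an at least 13-fold lower number from compound 1 to compound 4 (1.13 log units; beyond the scatter). The value of compound 1 is a limit and not a number, so that last step is only a bound: the limit of > 50000 nM in this assay, at which 1 of the 4 values shown sits.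

The step from compound 1 to compound 4 changes both the ester and the branched chain, so the compounds shown leave open which of the two carries it. A 1-carboxyethyl group or a 1-(methoxycarbonyl)-2-methylpropyl group at this nitrogen would separate the carboxylic acid from the isopropyl branch.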